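Replacing fluoro with methoxy in compound 3

This account rests on a few compounds, and the source may have more. Where it says the series, first, only, none or still open, it means among the compounds named here.

Compound 1 `CC1(C)[C@H]2CC[C@]1(C)N(Cc1cn(-c3ccccc3Br)nn1)C(=O)C2` gives 280 nM in a functional assay on PANC-1 cells (Homo sapiens) for inhibition, read by MTT assay, with a stated time of 24 h; a higher number here means a weaker inhibitor, a lower number a stronger inhibitor
Compound 2 `CC1(C)[C@H]2CC[C@]1(C)N(Cc1cn(-c3ccc(C#N)cc3)nn1)C(=O)C2` gives 250 nM
Compound 3 `CC1(C)[C@H]2CC[C@]1(C)N(Cc1cn(-c3ccccc3F)nn1)C(=O)C2` gives 150 nM

In this assay the value of compound 3 lies within the scatter of both other compounds. Compound 4 `COc1ccccc1-n1cc(CN2C(=O)C[C@@H]3CC[C@@]2(C)C3(C)C)nn1` differs from it by methoxy in place of fluoro on an aromatic carbon with methoxy in place of fluoro on an aromatic carbon, ortho to a large group. Within the data shown here, no methoxy compound has been measured yet. Among the measured compounds shown here, two measured steps bear on the change: a 1.9-fold lower number from compound 1 to compound 3 (0.27 log units; within the scatter) swaps the substituent on an aromatic carbon and a 1.7-fold lower number from compound 2 to compound 3 (0.22 log units; within the scatter) swaps the whole phenyl group. Neither exceeds the scatter, so no step beyond it is expected. The expected step is a 1.3-fold higher number from compound 3 to compound 4 (0.12 log units; within the scatter) and it stays small. Compound 4 is estimated at 200 nM with 90 nM to 450 nM as its expected range.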

Compound 4, half-maximal inhibitory concentration: 120 nM
Compound 4: middle estimate off by 1.7-fold (0.22 log units), on the high side, and the stated range covers the measured number.
By their numbers in this assay, from the lowest: compounds 4, 3, 2 and 1 (each within the scatter of the next, the first and the last beyond it).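

In this assay, the larger methoxy, with its two heavy atoms and one hydrogen-bond acceptor, is accepted on this aromatic carbon, ortho to a large group: the swap for fluoro gives a 1.3-fold lower number from compound 3 to compound 4 (0.10 log units; within the scatter). Unlike the earlier steps, the comparisons with the other two compounds pass the scatter, modestly, with a 2.1-fold lower number from compound 2 to compound 4 (0.32 log units; beyond the scatter) and a 2.3-fold lower number from compound 1 to compound 4 (0.37 log units; beyond the scatter). Nothing available explains these steps. The compounds shown leave open whether a hydroxyl, an amine or the longer ethoxy on this carbon would hold the number at this level.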